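Ester series: methoxy to trifluoromethyl swap, working notes

The compounds below may be only part of what the source reports. "The series", "measured", "known", "first", "only" and "open" are said of these compounds alone.

compound 1 `O=C(Oc1cccc2ccccc12)c1cccc(S)n1`: > 150000 nM
compound 2 `COc1cccc(COC(=O)c2cccc(S)n2)c1`: 93000 nM
compound 3 `O=C(OCc1c(F)cccc1F)c1cccc(=O)[nH]1`: 60000 nM

In an assay on isolated protein for inhibition of matrix metalloproteinase-9 (Homo sapiens) (a higher number here means a weaker inhibitor, a lower number a stronger inhibitor), compound 1 reports only a limit, not a number, namely (the limit of > 150000 nM in this assay, at which 1 of the 3 values shown sits). For the measured compounds named here, compound 2 and compound 3 give numbers that sit within the usual scatter of each other, so no order between them can be read; compound 2 is the only compound carrying a methoxy. Compound 4 `O=C(OCc1cccc(C(F)(F)F)c1)c1cccc(S)n1` is not yet measured. It differs from compound 2 by trifluoromethyl in place of methoxy on an aromatic carbon. Going by the values given here, no measured pair covers this change, so nothing in the set shows a shift beyond the scatter for it, and none beyond the scatter is expected in this assay. Compound 4 is expected near 80000 nM, between 30000 nM and 200000 nM, a step of a 1.2-fold lower number from compound 2 to compound 4 (0.07 log units; within the scatter) from compound 2.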

Compound 4, half-maximal inhibitory concentration: 126000 nM
Compound 4: the middle estimate sits 1.6-fold (0.20 log units) below what was measured; the measured number falls inside the stated range.
By their numbers in this assay, from the lowest: compounds 3, 2 and 4 (each within the scatter of the next, the first and the last beyond it). At a limit, above all of these: compound 1.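

In this assay, trifluoromethyl in place of methoxy on this aromatic carbon gives a 1.4-fold higher number from compound 2 to compound 4 (0.13 log units; within the scatter). At this position, the two groups cannot be told apart, even though the swap takes away the methoxy's hydrogen-bond acceptor. No measured property in the set bears on this step.

Still open, as far as these compounds go, is whether an amine or a carboxylic acid on the same aromatic carbon would move the number beyond the scatter. The same question applies to a longer chain there.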